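Varying the Aryl Hydrazone End of a Shared Urea Core

This account rests on a few compounds, and the source may have more. Where it says the series, first, only, none or still open, it means among the compounds named here.

The measured compounds:
compound 1 `CN(C)CCn1cnnc1-c1cc(Oc2ccc(NC(=O)N/N=C/c3ccc(O)c(Br)c3)cc2F)ccn1`, 430 nM
compound 2 `CN(C)CCn1cnnc1-c1cc(Oc2ccc(NC(=O)N/N=C/c3c[nH]c4ccccc34)cc2F)ccn1`, 1630 nM
compound 3 `Cc1cc(/C=N/NC(=O)Nc2ccc(Oc3ccnc(-c4nncn4CCN(C)C)c3)c(F)c2)cc(C)c1O`, 2010 nM

Three compounds share one core and differ only in the aryl group on a carbon with a double bond to nitrogen. In a functional assay on NCI-H460 cells (Homo sapiens) for cytotoxicity, read by MTT assay, with a stated time of 72 h (on this read-out higher numbers stand for weaker inhibition and lower numbers for stronger inhibition), compound 1 gives 430 nM, the lowest of the three numbers. Compound 2 sits higher, a 3.8-fold higher number from compound 1 to compound 2 (0.58 log units; beyond the scatter), and compound 3 stands highest of the three, a 4.7-fold higher number from compound 1 to compound 3 (0.67 log units; beyond the scatter). Between compound 2 and compound 3 the gap is small, a 1.2-fold higher number from compound 2 to compound 3 (0.09 log units; within the scatter), so these two cannot be ordered.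

Compound 4 `COc1ccc(/C=N/NC(=O)Nc2ccc(Oc3ccnc(-c4nncn4CCN(C)C)c3)c(F)c2)c(OC)c1` has not yet been measured in this assay. It differs from compound 3 by 2,4-dimethoxyphenyl in place of 4-hydroxy-3,5-dimethylphenyl on a carbon with a double bond to nitrogen. Among the compounds with values here, the 4-hydroxy-3,5-dimethylphenyl carries one hydrogen-bond donor, which the entering 2,4-dimethoxyphenyl does not; among the measured compounds the one with the lowest number, compound 1, also carries a hydroxyl on its aryl group, while the indolyl of compound 2 gives a higher number. Both steps from the aryl change were modest in size. Compound 4 is therefore expected to stay near the upper end, with the step of a 1.2-fold higher number from compound 3 to compound 4 (0.09 log units; within the scatter) expected to lie within the scatter or slightly beyond it. For compound 4 the estimated value is 2500 nM, with a range from 1000 nM to 6500 nM.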

Compound 4, half-maximal inhibitory concentration: 1570 nM
For compound 4 the middle estimate is 1.6-fold (0.20 log units) above the measured one, within the range that was stated.
By their numbers in this assay, from the lowest: compound 1; then compounds 4, 2 and 3 (each within the scatter of the next).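

In this assay, the 2,4-dimethoxyphenyl of compound 4 has no hydrogen-bond donor and has more hydrogen-bond acceptors than the 4-hydroxy-3,5-dimethylphenyl it replaces, yet the step (a 1.3-fold lower number from compound 3 to compound 4 (0.11 log units; within the scatter)) leaves the two compounds indistinguishable. The same holds against the 1H-indol-3-yl (a 1.0-fold lower number from compound 2 to compound 4 (0.02 log units; within the scatter)), so three quite different aryl groups on the carbon with a double bond to nitrogen now form a single level, and only the 3-bromo-4-hydroxyphenyl stands apart (a 3.7-fold higher number from compound 1 to compound 4 (0.56 log units; beyond the scatter)). A hydroxyl on the aryl group therefore does not by itself go with the lowest number: compound 3 carries one and compound 4 does not, while compound 1 alone differs from the rest, and nothing available here bears on why.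

The compounds shown leave open whether the gap of compound 1 follows its bromine, its hydroxyl or the two together, which a plain 3-bromophenyl, a 4-hydroxyphenyl or a 3-chloro-4-hydroxyphenyl at this place could separate. They also leave open how an aryl group bearing an amine or a carboxylic acid would read here.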